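A few compounds are considered here, and "the series" means these few. Any claim that something is new, unique, unknown or untested is made for them only; others in the source may bear on it.

Compound 1 `N#CC1=C(N)Oc2c(c3nc4ccccc4nc3c3ccccc23)C12C(=O)N(Cc1cnnn1-c1ccc(F)cc1)c1ccccc12` gives > 50000 nM in a functional assay on A549 cells (Homo sapiens) for antiproliferative activity, read by MTT assay, with a stated time of 48 h (a higher number here means a weaker inhibitor, a lower number a stronger inhibitor), which is a limit of the assay and not a number.
Compound 2 `N#CC1=C(N)Oc2c(c3nc4ccccc4nc3c3ccccc23)C12C(=O)N(Cc1cnnn1-c1ccc(Cl)cc1)c1ccccc12` gives > 50000 nM in this assay, again only a limit.

Compound 2 therefore stands at the upper edge of what this assay can report; this is the situation described by the limit of > 50000 nM in this assay, at which 2 of the 2 values shown sit. Among the measured compounds shown here, the one measured step, a step that the two limits leave unreadable from compound 1 to compound 2, cannot be sized. Compound 3 `N#CC1=C(N)Oc2c(c3nc4ccccc4nc3c3ccccc23)C12C(=O)N(Cc1cnnn1-c1ccccc1Cl)c1ccccc12` differs from compound 2 by 2-chlorophenyl in place of 4-chlorophenyl on an aromatic nitrogen. With no readable step to lean on, compound 3 is expected to remain at the limit, a change of a number no higher from compound 2 to compound 3 (the limit leaves the size open), and its estimated value is 50000 nM, between 15000 nM and 150000 nM.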

Compound 3, half-maximal inhibitory concentration: 42600 nM
Compound 3: middle estimate off by 1.2-fold (0.07 log units), on the high side, and the stated range covers the measured number.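

Among the compounds shown here, compound 3, with 2-chlorophenyl on the aromatic nitrogen, is the first here to give a readable number in this assay, 42600 nM. Compound 1 and compound 2 remain limits of the assay and not numbers: the limit of > 50000 nM in this assay, at which 2 of the 3 values shown sit. The change gives an at least 1.1-fold lower number from compound 2 to compound 3 (0.06 log units; that floor lies within the scatter) and an at least 1.1-fold lower number from compound 1 to compound 3 (0.06 log units; that floor lies within the scatter), so these floors do not establish a real gain in potency.

Still open, as far as these compounds go, is whether 3-chlorophenyl would read differently from 2-chlorophenyl. Also open, from the compounds shown here alone, is whether an amine or a carboxylic acid on this phenyl ring would move the number further from the limit.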